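The source may hold more compounds than are shown below. What is called first, only, known or untested is meant among the compounds shown, and "the series" means these compounds.

Measured so far in a physicochemical assay for pharmacokinetics, read by HPLC, in phosphate buffer, at pH 7.4; a higher number here means that the compound lasts longer, a lower number that the compound disappears faster:
- compound 1 `CCCC(CCC)C(=O)N(C)/N=N/c1ccc(C(C)=O)cc1` gives > 40 h (a limit, not a number)
- compound 2 `CCCC(CCC)C(=O)N(C)/N=N/c1ccc(C(=O)OC)cc1` gives 31.4 h (a true half-life)

Among the measured compounds shown here, compound 2 holds the only true number so far, with 31.4 h as its half-life. For compound 1 the reading is the limit of > 40 h in this assay, at which 1 of the 2 values shown sits, which is a limit and not a number.

The next compound, compound 3 `CCCC(CCC)C(=O)N(C)/N=N/c1ccc(Cl)cc1`, carries chloro in place of methoxycarbonyl on an aromatic carbon, para to a large group (chloro in place of methoxycarbonyl on an aromatic carbon). For the measured compounds named here, the one measured step that bears on this is an at least 1.2-fold lower number from compound 1 to compound 2 (0.10 log units; that floor lies within the scatter), made by methoxy in place of methyl on a carbonyl carbon. That step alters the group that now leaves but keeps its carbonyl, whereas compound 3 loses the whole group, so it is only a loose guide. Resting on compound 2 at 31.4 h and that single step, no change beyond the scatter is expected in this assay. The estimated step is a 1.2-fold higher number from compound 2 to compound 3 (0.08 log units; within the scatter), which is expected to stay within the scatter. For compound 3 the estimate is 38 h, with an expected range from 18 h to 80 h for its half-life.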

Compound 3, half-life: 27.3 h
Compound 3: middle estimate off by 1.4-fold (0.14 log units), on the high side, within the range that was stated.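

Chloro, with its single heavy atom and no hydrogen-bond acceptor, replaces the four heavy atoms of methoxycarbonyl on an aromatic carbon, para to a large group, and this assay shows a 1.2-fold lower number from compound 2 to compound 3 (0.06 log units; within the scatter), so this position does not need a carbonyl for the half-life to stay in the same range, something the earlier compounds could not show since both carry one there. Chloro in place of acetyl at the same position gives an at least 1.4-fold lower number from compound 1 to compound 3 (0.16 log units; that floor lies within the scatter), and this too shows no change beyond the scatter. That step can only be read as a floor, since compound 1 gives a limit and not a number: the limit of > 40 h in this assay, at which 1 of the 3 values shown sits.

Among the compounds shown here, all the steps at this position so far stay within the scatter, so it remains open whether any group placed here, such as an amine, a carboxylic acid or a hydroxyl, would move the half-life beyond it. On these data alone, the rest of the molecule is the same in all three compounds, so what a shorter chain on the other side of the shared core would do also remains open.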